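Sulfonate aryl group changes in a piperidine-imidazole P2X7 series

The source may report more compounds than this note shows. Statements on the series, on what has been measured and on what is new or still open speak of the compounds shown alone.

Measured so far in an assay on HEK293 cells for antagonist activity at P2X purinoceptor 7 (Homo sapiens), read by fluorescence, with a stated time of 2 h; on this read-out lower numbers stand for stronger inhibition and higher numbers for weaker inhibition:
compound 1 `CNC(=O)c1cccc(S(=O)(=O)Oc2ccc(-c3cncn3C3CCN(C(=O)c4ccc(Cl)c(C(F)(F)F)c4)CC3)cc2)c1` gives 112 nM
compound 2 `CS(=O)(=O)c1ccc(C(=O)N2CCC(n3cncc3-c3ccc(OS(=O)(=O)c4cccc5cnccc45)cc3)CC2)cc1` gives 25 nM
compound 3 `CS(=O)(=O)c1ccc(C(=O)N2CCC(n3cncc3-c3ccc(OS(=O)(=O)c4cccc(C#N)c4)cc3)CC2)cc1` gives 143 nM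

For the measured compounds named here, compound 3 gives the highest number of the three, although compound 1 lies within the scatter of it; compound 2 stands clearly lower, and the one-place step a 5.7-fold higher number from compound 2 to compound 3 (0.76 log units; beyond the scatter) is the only step of the set. Compound 4 `CNC(=O)c1cccc(S(=O)(=O)Oc2ccc(-c3cncn3C3CCN(C(=O)c4ccc(S(C)(=O)=O)cc4)CC3)cc2)c1` is not yet measured. Against compound 3 the change is methylcarbamoyl in place of cyano on an aromatic carbon. Going by the values given here, no measured step bears directly on this change: compound 1 carries the same 3-(methylcarbamoyl)phenyl group but differs from compound 3 in the benzoyl part as well, so the two values of compound 1 and compound 3, which sit within the scatter of each other, are all that can be read. On that basis the step of a 1.2-fold lower number from compound 3 to compound 4 (0.08 log units; within the scatter) is expected to stay within the scatter, with no clear direction. Compound 4 is therefore estimated at 120 nM in this assay, with a range from 50 nM to 300 nM.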

Compound 4, half-maximal inhibitory concentration: 202 nM
Estimate against measurement, compound 4: 1.7-fold (0.23 log units) below; low and high end bracket the measured number.
By their numbers in this assay, from the lowest: compound 2; then compounds 1, 3 and 4 (each within the scatter of the next).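

In this assay, the direct comparison at this position, with the 4-(methylsulfonyl)phenyl group held fixed, gives a 1.4-fold higher number from compound 3 to compound 4 (0.15 log units; within the scatter), so methylcarbamoyl and cyano are not told apart here. Isoquinolin-5-yl on the sulfonyl sulfur stays clearly separate from a second replacement as well, with an 8.1-fold higher number from compound 2 to compound 4 (0.91 log units; beyond the scatter), alongside a 5.7-fold higher number from compound 2 to compound 3 (0.76 log units; beyond the scatter) for 3-cyanophenyl. With 3-(methylcarbamoyl)phenyl held fixed, 4-(methylsulfonyl)phenyl in place of 4-chloro-3-(trifluoromethyl)phenyl gives a 1.8-fold higher number from compound 1 to compound 4 (0.26 log units; within the scatter), so that exchange on the carbonyl carbon does not separate the two compounds either.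

No available data explain any of these steps. Still open, going by these compounds, is whether an amine or a carboxylic acid in place of methylcarbamoyl would separate from these values, and whether isoquinolin-5-yl keeps its separation when paired with 4-chloro-3-(trifluoromethyl)phenyl.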